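Adding a phenylethenyl group to compound 2

The source may hold more compounds than are shown below. What is called first, only, known or untested is meant among the compounds shown, and "the series" means these compounds.

compound 1 (`BrCCCCOc1c(Br)cc(Br)cc1Oc1ccc(Br)cc1Br`): 25.9 ug/mL
compound 2 (`CN1CCN(CCCCCOc2c(Br)cc(Br)cc2Oc2ccc(Br)cc2Br)CC1`): 48.3 ug/mL
compound 3 (`BrCCCCCCOc1c(Br)cc(Br)cc1Oc1ccc(Br)cc1Br`): 37.8 ug/mL

In a functional assay on HL-60 cells (Homo sapiens) for cytotoxicity, read by MTT assay, with a stated time of 24 h (on this read-out higher numbers stand for weaker inhibition and lower numbers for stronger inhibition), compound 2 stands level with the other two, as a 1.9-fold higher number from compound 1 to compound 2 (0.27 log units; within the scatter) and a 1.3-fold lower number from compound 2 to compound 3 (0.11 log units; within the scatter) both lie within the scatter. Compound 4 (`Brc1ccc(Oc2cc(Br)cc(Br)c2OCCCCCN2CCN(C/C=C/c3ccccc3)CC2)c(Br)c1`) differs from compound 2 by 2-phenylethenyl in place of hydrogen on a saturated chain carbon bound to an amine nitrogen in a ring, which also reads as methyl to 3-phenylprop-2-en-1-yl. Among the measured compounds shown here, no measured step touches this place. The nearest guides are changes at the chain end, namely those two steps and a 1.5-fold higher number from compound 1 to compound 3 (0.16 log units; within the scatter), and all of them are small. Only a modest shift is therefore expected. The estimated change is a 1.4-fold lower number from compound 2 to compound 4 (0.14 log units; within the scatter), which means none beyond the scatter. For compound 4 the expected value is 35 ug/mL, with an estimated range from 14 ug/mL to 75 ug/mL.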

Compound 4, half-maximal inhibitory concentration: 47.2 ug/mL
Beside the measured number, compound 4's estimate is 1.3-fold (0.13 log units) below it; low and high end bracket the measured number.
By their numbers in this assay, from the lowest: compounds 1, 3, 4 and 2 (each within the scatter of the next).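

In this assay the exchange of hydrogen for 2-phenylethenyl gives a 1.0-fold lower number from compound 2 to compound 4 (0.01 log units; within the scatter) on a saturated chain carbon bound to an amine nitrogen in a ring. Among the compounds shown here, earlier steps changed only the chain end, so this is the first sign that this place accepts an added aromatic ring and double bond with no change beyond the scatter. No measured evidence here offers an explanation for this result.

As far as these compounds go, it remains open whether a benzyl group, which lacks the double bond, would read the same at this place, or whether an amine on the added ring would shift the number.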